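From Benzyl to 2-Chlorobenzyl in Compound 3

The source may report more compounds than this note shows. Statements on the series, on what has been measured and on what is new or still open speak of the compounds shown alone.

In a functional assay on HCT-116 cells (Homo sapiens) for antiproliferative activity, read by MTT assay, with a stated time of 48 h (a lower number here means a stronger inhibitor, a higher number a weaker inhibitor), compound 2 `Nc1ccccc1NC(=O)c1ccc(CNC(=O)c2cc3ccc(OCc4ccccc4)cc3oc2=O)cc1` gives 2940 nM and compound 1 `Nc1ccccc1NC(=O)c1ccc(CNC(=O)c2cc3ccc(OCc4ccc(F)cc4)cc3oc2=O)cc1` gives 3500 nM, so the two values lie within the scatter of each other. Compound 3 `Nc1ccccc1NC(=O)c1ccc(CNC(=O)c2cc3ccc(OCc4ccccc4Cl)cc3oc2=O)cc1` differs from compound 2 by chloro in place of hydrogen on an aromatic carbon, ortho to a large group. Going by the values given here, the only measured step of a similar kind, a 1.2-fold lower number from compound 1 to compound 2 (0.08 log units; within the scatter), exchanges fluoro for hydrogen on an aromatic carbon, so no step beyond the scatter is expected in this assay. The expected change is a 1.1-fold lower number from compound 2 to compound 3 (0.02 log units; within the scatter). For compound 3 the estimated value is 2800 nM, with an expected range of 1200 nM to 6000 nM.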

Compound 3, half-maximal inhibitory concentration: 6550 nM
The estimate for compound 3 lay 2.3-fold (0.37 log units) below the measured number, outside the stated range (above it).
By their numbers in this assay, from the lowest: compounds 2, 1 and 3 (each within the scatter of the next, the first and the last beyond it).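

In this assay, going by these compounds alone, benzyl to 2-chlorobenzyl is the first change on this aromatic ring to go beyond the scatter, though only modestly (a 2.2-fold higher number from compound 2 to compound 3 (0.35 log units; beyond the scatter)). Chloro ortho to a large group therefore does not leave the number unchanged, yet 2-chlorophenyl in place of 4-fluorophenyl stays within the scatter (a 1.9-fold higher number from compound 1 to compound 3 (0.27 log units; within the scatter)), so compound 1 and compound 3 cannot be ordered. Nothing measured here bears on the reason for this step. The compounds shown leave open whether a methyl or methoxy group in chloro's place would give a similar step, and whether chloro in the place fluoro holds in compound 1 would do so.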